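Dimethylurea in Place of Ethylurea on the Shared Core

The source may hold more compounds than are shown below. What is called first, only, known or untested is meant among the compounds shown, and "the series" means these compounds.

Compound 1 `CC(=O)N1CCC[C@H]1C(=O)N1CCC(NS(=O)(=O)c2cc(S(=O)(=O)c3ccccc3)ccc2C(F)(F)F)CC1`: 250 nM
Compound 2 `CCNC(=O)N1CCC[C@H]1C(=O)N1CCC(NS(=O)(=O)c2cc(S(=O)(=O)c3ccccc3)ccc2C(F)(F)F)CC1`: 90 nM

In a functional assay on U2OS cells for antagonist activity at proto-oncogene Wnt-3 (Homo sapiens), read by a luciferase reporter, with a stated time of 18 h (on this read-out higher numbers stand for an effect only at larger amounts of compound and lower numbers for an effect already at smaller amounts), compound 1 gives 250 nM. Compound 2 stands lowest of the two numbers; its nearest neighbour is compound 1, and the step of a 2.8-fold lower number from compound 1 to compound 2 (0.44 log units; beyond the scatter) is beyond the scatter. Compound 3 `CN(C)C(=O)N1CCC[C@H]1C(=O)N1CCC(NS(=O)(=O)c2cc(S(=O)(=O)c3ccccc3)ccc2C(F)(F)F)CC1` has not yet been measured. It differs from compound 2 by dimethylamino in place of ethylamino on a carbonyl carbon. Among the compounds with values here, the only measured step, from compound 1 to compound 2, exchanged a methyl for an ethylamino on the same carbonyl carbon, so it bears on this change only indirectly; no measured pair covers the exchange of ethylamino for dimethylamino. For compound 3 a modest step back toward the number of compound 1, or no step beyond the scatter, is expected, as a 2.2-fold higher number from compound 2 to compound 3 (0.35 log units; beyond the scatter). Compound 3 is therefore estimated at 200 nM, within 60 nM to 650 nM.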

Compound 3, half-maximal effective concentration: 160 nM
Compound 3: middle estimate off by 1.3-fold (0.10 log units), on the high side, and the stated range covers the measured number.
By their numbers in this assay, from the lowest: compounds 2, 3 and 1 (each within the scatter of the next, the first and the last beyond it).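

In this assay the exchange of ethylamino for dimethylamino on the carbonyl carbon keeps the same heavy atoms but goes from 1 hydrogen-bond donor to 0, and it gives a 1.8-fold higher number from compound 2 to compound 3 (0.25 log units; within the scatter), so the data do not show that the amide hydrogen of compound 2 is needed at this position. Dimethylamino in place of methyl gives a 1.6-fold lower number from compound 1 to compound 3 (0.19 log units; within the scatter), which leaves compound 3 not separable from either compound 1 or compound 2, although those two lie apart by a 2.8-fold lower number from compound 1 to compound 2 (0.44 log units; beyond the scatter). No measurement offers an explanation for these numbers.

Going by these compounds, it remains open whether methylamino, a longer chain such as propylamino, or a cyclic amine such as morpholine on this carbonyl carbon would move the number beyond the scatter. On these data alone, whether the ethylamino to dimethylamino exchange reads the same on another core also remains open.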